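Swapping the Ester Tail: Butyl to Phenyl

The source may report more compounds than this note shows. Statements on the series, on what has been measured and on what is new or still open speak of the compounds shown alone.

The measured compounds, all sharing one core:
- compound 1 `O=c1c(CCO)c(-c2ccccc2Cl)c2cc(Cl)ccc2n1-c1ccccc1` gives 26000 nM
- compound 2 `CCCCC(=O)OCCc1c(-c2ccccc2Cl)c2cc(Cl)ccc2[nH]c1=O` gives 200000 nM
- compound 3 `CC(=O)N1CCC(C(=O)OCCc2c(-c3ccccc3Cl)c3cc(Cl)ccc3[nH]c2=O)CC1` gives 82000 nM

These numbers come from an ADME assay on HepG2 2.2.15 cells (Homo sapiens) for cytotoxicity; a higher number here means that more compound is tolerated, a lower number that less compound is tolerated. Compound 2 stands highest of the three, so it is the best tolerated of those measured. Within the data shown here, its nearest neighbour in number is compound 3, and the only single-point step among the measured compounds runs between these two: a 2.4-fold lower number from compound 2 to compound 3 (0.39 log units; beyond the scatter), a modest lowering that sits at the same carbonyl carbon that is altered here.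

Compound 4 `O=C(OCCc1c(-c2ccccc2Cl)c2cc(Cl)ccc2[nH]c1=O)c1ccccc1` differs from compound 2 in that way: phenyl in place of butyl on a carbonyl carbon. Among the measured compounds shown here, only the step from compound 2 to compound 3 bears on this, and it was modest; no measured pair shows a phenyl taking this place. A small lowering or a change within the scatter is therefore the expectation. The expected step is a 1.7-fold lower number from compound 2 to compound 4 (0.22 log units; within the scatter). Compound 4 is thus estimated at 120000 nM, with a range from 50000 nM to 300000 nM.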

Compound 4, half-maximal cytotoxic concentration: 43000 nM
Compound 4: middle estimate off by 2.8-fold (0.45 log units), on the high side, and the stated range ends above it.
By their numbers in this assay, from the lowest: compounds 1, 4 and 3 (each within the scatter of the next, the first and the last beyond it); then compound 2.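

In this assay, the step with phenyl in place of butyl on this carbonyl carbon is a 4.7-fold lower number from compound 2 to compound 4 (0.67 log units; beyond the scatter) and lies beyond the scatter, as does the earlier step of a 2.4-fold lower number from compound 2 to compound 3 (0.39 log units; beyond the scatter). Among the compounds shown, butyl is therefore better tolerated at this place than either of the two ring-bearing groups, so the lower number is not tied to the 1-acetylpiperidin-4-yl group alone, while the comparison of those two groups gives a 1.9-fold lower number from compound 3 to compound 4 (0.28 log units; within the scatter) and does not separate them. Nothing measured here explains why the number falls when butyl leaves.

As far as these compounds go, how a longer chain such as hexyl, or a shorter one such as methyl, would compare with butyl at this carbonyl carbon remains open. So does the outcome for a cyclohexyl ring, or for a phenyl ring carrying an amine or a carboxylic acid.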